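Three Limits and a Fourth Compound Awaiting Measurement

This account rests on a few compounds, and the source may have more. Where it says the series, first, only, none or still open, it means among the compounds named here.

Compound 1 `Cc1ccccc1Nc1nc(C)c(C(=O)/C=C/c2ccc(Cl)cc2)s1` gives > 25000 nM in a functional assay on PC-3 cells (Homo sapiens) for cytotoxicity, read by MTT assay; a higher number here means a weaker inhibitor, a lower number a stronger inhibitor.
Compound 2 `Cc1nc(Nc2cccc(Cl)c2)sc1C(=O)/C=C/c1ccc(Cl)cc1` gives > 25000 nM in this assay.
Compound 3 `COc1cccc(/C=C/C(=O)c2sc(Nc3ccccc3C)nc2C)c1` gives > 25000 nM in this assay.

Each of these three readings is a limit of the assay, not a number, as the limit of > 25000 nM in this assay, at which 3 of the 3 values shown sit, shows. With all three at that limit, the step that the two limits leave unreadable from compound 1 to compound 2, made by 3-chlorophenyl in place of 2-methylphenyl on a nitrogen on an aromatic ring, cannot be sized. The cores of compound 1 and compound 3 differ by 3-methoxyphenyl in place of 4-chlorophenyl on a double-bonded chain carbon bound to a double-bonded chain carbon, and a step that the two limits leave unreadable from compound 1 to compound 3 is equally unreadable.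

Compound 4 `COc1cccc(/C=C/C(=O)c2sc(Nc3cccc(Cl)c3)nc2C)c1` has not yet been measured in this assay. It differs from compound 3 by 3-chlorophenyl in place of 2-methylphenyl on a nitrogen on an aromatic ring, the same change that separates compound 1 from compound 2, at a place worded identically in both. Because compound 2 gives > 25000 nM after that same change, the expected step is a step that the limit leaves unreadable from compound 3 to compound 4. Compound 4 is therefore estimated at 35000 nM.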

Compound 4, half-maximal inhibitory concentration: > 25000 nM
Compound 4 gave a limit, no number (the forecaster's own chance of this, stated with the estimate: 85%); the middle value lies beyond the limit too.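

No new step can be read from compound 4 against compound 3 or compound 2, since all of them sit at one limit: the limit of > 25000 nM in this assay, at which 4 of the 4 values shown sit.
The compounds shown leave open how strongly any of them acts on these cells, and whether either change alters that.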